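The compounds below may be only part of what the source reports. "The series", "measured", "known", "first", "only" and "open" are said of these compounds alone.

Measured compounds:
Compound 1, `Cc1cccc(-c2nc3cc(C)ccc3c(=O)[nH]2)c1`: in an assay on isolated protein for inhibition of DNA topoisomerase 1 (Homo sapiens), with a stated time of 30 min, tested at 100 uM (a lower number here means a weaker effect, a higher number a stronger effect of the compound at the concentration tested), compound 1 gives 100%.
Compound 2, `Cc1ccc2c(=O)[nH]c(-c3ccccc3C)nc2c1`: in this assay compound 2 gives 100%.
Compound 3, `Cc1ccc2c(=O)[nH]c(-c3ccccc3OC(F)(F)F)nc2c1`: in this assay compound 3 gives 100%.

Compound 3 stands level with compounds 1 and 2 at the digits reported; all three reach the same reading in this assay, and none can be called stronger than another. Among the measured compounds shown here, the one single-site step among the measured compounds, no change at the digits printed from compound 2 to compound 3 (within the scatter), brought trifluoromethoxy in place of methyl on an aromatic carbon without moving the reading beyond the scatter.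

Compound 4, `Cc1ccc2c(=O)[nH]c(-c3ccccc3N(C)C)nc2c1`, differs from compound 3 in one place: dimethylamino in place of trifluoromethoxy on an aromatic carbon. For the measured compounds named here, this is the only step that bears on the question, and it shows a substituent exchange at the same aromatic carbon leaving the reading unchanged. Since the step from compound 2 to compound 3 gave no change, the change to dimethylamino is expected to give no step beyond the scatter, so a number 2 percentage points lower from compound 3 to compound 4 (within the scatter) is estimated. Compound 4 is therefore expected to give about 98% in this assay, within a range from 85% to 100%.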

Compound 4, a percentage reported as inhibition, at one concentration (the size of the read-out at that concentration, not a potency): 82.1%
The estimate for compound 4 lay 15.9 percentage points above the measured number; measured number outside the range, below it.
By their numbers in this assay, from the lowest: compound 4; then compounds 1, 2 and 3 (each within the scatter of the next).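

At this aromatic carbon, ortho to a large group, the substituent does matter in this assay: dimethylamino in place of trifluoromethoxy gave a number 17.9 percentage points lower from compound 3 to compound 4 (beyond the scatter), and dimethylamino in place of methyl gave a number 17.9 percentage points lower from compound 2 to compound 4 (beyond the scatter). Among the compounds shown here, the earlier exchange of methyl for trifluoromethoxy had left the reading in place, so dimethylamino is the first of these three groups to separate from the others at this position. Nothing on hand accounts for this drop, so the step stands as an observation without an explanation.

The compounds shown leave open whether the lower reading is particular to dimethylamino or would also appear with a plain amino group, a methoxy group or diethylamino at the same carbon. Readings at a single concentration also leave open whether compound 2 and compound 3 differ at lower concentrations.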